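Adding a 2-bromophenyl to the benzyl ether of compound 3

This account rests on a few compounds, and the source may have more. Where it says the series, first, only, none or still open, it means among the compounds named here.

Measured so far:
compound 1, `COc1ccccc1COc1ccccc1/C=C/C=C1\SC(=S)NC1=O`, 98%
compound 2, `O=C1NC(=O)/C(=C/C=C/c2ccccc2OCc2ccccc2Br)S1`, 50%
compound 3, `COc1ccccc1/C=C/C=C1\SC(=S)NC1=O`, 69%

In a functional assay on DLD-1 cells (Homo sapiens), read by microscopy and crystal violet staining, with a stated time of 20 h, tested at 10 ug/mL (on this read-out higher numbers stand for more inhibition at the one concentration tested (going by the name of the read-out) and lower numbers for less inhibition), compound 3 gives 69%, the second highest of the three numbers; compound 1 stands higher and compound 2 lower, each beyond the scatter. Compound 4, `O=C1NC(=S)S/C1=C\C=C\c1ccccc1OCc1ccccc1Br`, has not yet been measured. It differs from compound 3 in one place: 2-bromophenyl in place of hydrogen on a saturated chain carbon bound to an oxygen on an aromatic ring.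

Going by the values given here, one measured step bears on this. Going a number 29 percentage points lower from compound 1 to compound 3 (beyond the scatter), the change was the removal of a 2-methoxyphenyl from the same saturated chain carbon bound to an oxygen on an aromatic ring; putting a 2-bromophenyl in there is the reverse kind of change, so a rise of roughly that size is expected. Among the compounds with values here, compound 2 carries the same 2-bromophenyl but a different core, and it gives 50%; no step links it to compound 4, so it only cautions against assuming the gain is certain. On balance compound 4 is expected to show a number 19 percentage points higher from compound 3 to compound 4 (beyond the scatter), landing at an estimated 88%, with a range from 68% to 99%.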

Compound 4, a percentage reported as inhibition, at one concentration (the size of the read-out at that concentration, not a potency): 78%
Beside the measured number, compound 4's estimate is 10 percentage points above it; the range from low to high includes it.
By their numbers in this assay, from the lowest: compound 2; then compounds 3 and 4 (each within the scatter of the next); then compound 1.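

In this assay, putting a 2-bromophenyl on this saturated chain carbon gives a number 9 percentage points higher from compound 3 to compound 4 (within the scatter) and so shows that the position accepts this added ring, with no clear change in inhibition. What sits on that added ring makes a difference, since bromo in place of methoxy on an aromatic carbon gives a number 20 percentage points lower from compound 1 to compound 4 (beyond the scatter) and the added ring alone therefore does not bring the higher number of compound 1. The core also matters with the side chain held the same, as changing it gives a number 28 percentage points higher from compound 2 to compound 4 (beyond the scatter) in this pair. Still open, as far as these compounds go, is how a plain phenyl, a 2-chlorophenyl or a chain ending in an amine would read on this carbon, and whether the 2-methoxyphenyl would keep its high number on the core of compound 2. Nothing at hand explains these differences.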